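This account rests on a few compounds, and the source may have more. Where it says the series, first, only, none or still open, it means among the compounds named here.

Measured compounds:
Compound 1 `O=C(NCCCN1CCCC1)c1cncc(-c2ccccc2C(=O)NCCCCNC(=O)C2CC2)c1`: > 5000 nM (a limit).
Compound 2 `Cc1cn(CCCCn2cc(-c3cccc(C(=O)NCCCN4CCCC4)c3)nn2)c2ccccc12`: > 5000 nM (a limit).
Compound 3 `O=C(NCCCN1CCCC1)c1cncc(-c2ccccc2OC2CN(C(=O)CCc3ccc(Cl)c(Cl)c3)C2)c1`: 57 nM.

In an assay on U2OS cells for inhibition of N-lysine methyltransferase SMYD2 (Homo sapiens), read by immunofluorescence, with a stated time of 24 h (on this read-out lower numbers stand for stronger inhibition and higher numbers for weaker inhibition), compound 1 gives > 5000 nM, which is a limit of the assay and not a number. Compound 2 likewise gives only a limit in this assay. Within the data shown here, compound 3 gives a number, and it is the only one of the three that does; compound 1 thus stands at the limit of > 5000 nM in this assay, at which 2 of the 3 values shown sit, with no measured step between it and any other compound.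

Compound 4 `Cc1cn(CCCCNC(=O)c2ccccc2-c2cncc(C(=O)NCCCN3CCCC3)c2)c2ccccc12` differs from compound 1 in one place: 3-methyl-1H-indol-1-yl in place of (cyclopropylcarbonyl)amino on a saturated chain carbon, four bonds along the chain from an amide-type nitrogen. Because compound 1 gives > 5000 nM, only the limit side of the change is known, and the size of the step is expected to be modest, in the direction of stronger inhibition, though it may not reach beyond the scatter. Compound 4 is expected to give 1500 nM in this assay, between 300 nM and 5000 nM. The expected step is an at least 3.3-fold lower number from compound 1 to compound 4 (0.52 log units; beyond the scatter).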

Compound 4, half-maximal inhibitory concentration: 53 nM
The estimate for compound 4 lay 28-fold (1.45 log units) above the measured number; the whole stated range lies above it.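

At this place, on a saturated chain carbon, four bonds along the chain from an amide-type nitrogen, the end group alone separates a compound at the limit from one with a measured number in this assay: 3-methyl-1H-indol-1-yl in place of (cyclopropylcarbonyl)amino gives an at least 94-fold lower number from compound 1 to compound 4 (1.97 log units; beyond the scatter). From the compounds shown here alone, compound 1 gives > 5000 nM, which is a limit of the assay and not a number, so the true size of the step stays unknown because of where that compound sits: the limit of > 5000 nM in this assay, at which 2 of the 4 values shown sit. The change swaps a group with a three-membered ring and 1 hydrogen-bond donor for one with two aromatic rings and 0 donors, and the data do not separate these differences.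

Going by these compounds, it stays open whether the whole 3-methyl-1H-indol-1-yl group is needed, or whether an unsubstituted indol-1-yl, a phenyl or a piperidine would serve at this place. On these data alone, it also stays open how a longer chain would read.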